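Swapping the trifluoromethylphenyl arm for a hydroxypyridinyl group

A few compounds are considered here, and "the series" means these few. Any claim that something is new, unique, unknown or untested is made for them only; others in the source may bear on it.

Compounds measured so far:
compound 1 `CC(=O)Nc1ccc(NC(=O)c2cc(Cl)ccc2O)c(Cl)c1` — "not determined" (no result reported)
compound 2 `O=C(Nc1ccc(NCc2ccc(C(F)(F)F)cc2)cc1Cl)c1cc(Cl)ccc1O` — 62700 nM
compound 3 `O=C(Nc1ccc(NCc2cccc(C(F)(F)F)c2)cc1Cl)c1cc(Cl)ccc1O` — 13300 nM

Within the data shown here, in an ADME assay on A549 cells (Homo sapiens) for cytotoxicity, read by resazurin assay, with a stated time of 48 h (a higher number here means that more compound is tolerated, a lower number that less compound is tolerated), compound 3 gives 13300 nM, the lowest of the two numbers available; compound 2 gives 62700 nM, and the one step connecting them, a 4.7-fold lower number from compound 2 to compound 3 (0.67 log units; beyond the scatter), is beyond the scatter. Compound 1 has no result in this assay.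

Compound 4 `O=C(Nc1ccc(NCc2ccc(O)nc2)cc1Cl)c1cc(Cl)ccc1O` is the next compound in this series. It differs from compound 3 in one place: 6-hydroxypyridin-3-yl in place of 3-(trifluoromethyl)phenyl on a saturated chain carbon bound to a nitrogen on an aromatic ring. Among the measured compounds shown here, no measured step bears directly on this swap; the single step, from compound 2 to compound 3, only shows that moving the same group from one position to another already shifted the number by a 4.7-fold lower number from compound 2 to compound 3 (0.67 log units; beyond the scatter), so the spread to be allowed for here is wide. With nothing pointing firmly either way, the expectation for compound 4 is a number somewhat higher than that of compound 3, a step of about a 2.3-fold higher number from compound 3 to compound 4 (0.35 log units; beyond the scatter), with considerable uncertainty. Compound 4 is therefore estimated at 30000 nM, within a range of 8000 nM to 100000 nM.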

Compound 4, half-maximal cytotoxic concentration: 98500 nM
Compound 4: middle estimate off by 3.3-fold (0.52 log units), on the low side; low and high end bracket the measured number.
By their numbers in this assay, from the lowest: compound 3; then compounds 2 and 4 (each within the scatter of the next).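

In this assay, the 6-hydroxypyridin-3-yl group on the saturated chain carbon gives a 7.4-fold higher number from compound 3 to compound 4 (0.87 log units; beyond the scatter), showing that the number at this position responds to a change of ring as well as to a shift of the trifluoromethyl group. Set against the 4-(trifluoromethyl)phenyl group, the same ring gives a 1.6-fold higher number from compound 2 to compound 4 (0.20 log units; within the scatter), so two quite different arms read alike here, while compound 3 alone stands apart with the lowest number. Nothing measured here accounts for either step.

The compounds shown leave open whether the ring nitrogen or the hydroxyl group goes with the higher number, a question that an unsubstituted pyridine ring and a hydroxyphenyl ring could separate. They also leave open how a carboxylic acid or an amine on this arm would read.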